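The source may hold more compounds than are shown below. What is called first, only, known or untested is meant among the compounds shown, and "the series" means these compounds.

Among the measured compounds shown here, in a functional assay on HL-60 cells (Homo sapiens) for cytotoxicity, read by WST assay, with a stated time of 48 h (a lower number here means that less compound is needed, a higher number that more compound is needed for the effect), compound 2 `Cc1ccccc1C[C@H]1COC(=O)[C@@H]1Cc1ccc(Cl)c(Cl)c1` gives 22000 nM, the lower of the two numbers measured so far. Compound 1 `COCOc1ccc(C[C@H]2C(=O)OC[C@@H]2Cc2ccccc2)cc1` gives 71000 nM, a higher number, and that gap lies beyond the scatter. Compound 3 `O=C1OC[C@H](Cc2ccc(F)c(F)c2)[C@H]1Cc1ccc(Cl)c(Cl)c1` differs from compound 2 in one place: 3,4-difluorophenyl in place of 2-methylphenyl on a saturated chain carbon bound to a saturated ring carbon. For the measured compounds named here, no measured pair carries this change, so its effect is not known from the data. For compound 3 the step of a 1.5-fold lower number from compound 2 to compound 3 (0.17 log units; within the scatter) is expected to be small, leaning toward a lower number but hardly beyond the scatter. Compound 3 is therefore estimated at 15000 nM in this assay, with a range from 6000 nM to 40000 nM.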

Compound 3, half-maximal effective concentration: 25000 nM
Beside the measured number, compound 3's estimate is 1.7-fold (0.22 log units) below it, within the range that was stated.
By their numbers in this assay, from the lowest: compounds 2 and 3 (each within the scatter of the next); then compound 1.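

In this assay, among the compounds shown here, 3,4-difluorophenyl in place of 2-methylphenyl on a saturated chain carbon bound to a saturated ring carbon gives a 1.1-fold higher number from compound 2 to compound 3 (0.06 log units; within the scatter) and so provides the first reading of a change at this position. Exchanging these two aromatic groups, neither with hydrogen-bond donors or acceptors, leaves the number within the scatter. No evidence at hand explains this result.

The compounds shown leave open whether an amine or a carboxylic acid at this position would take the number in this assay beyond the scatter. They also leave open how a longer chain carrying 3,4-difluorophenyl would read.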